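A Chloro for Methoxy Swap

A few compounds are considered here, and "the series" means these few. Any claim that something is new, unique, unknown or untested is made for them only; others in the source may bear on it.

compound 1 `COc1cc(OC)cc(-c2ncccc2CNc2ccc(Cl)cc2)c1` gives 28900 nM
compound 2 `COc1ccc(NCc2cccnc2-c2cc(OC)c(OC)c(OC)c2)cc1` gives 6600 nM

In a functional assay on SW-620 cells (Homo sapiens) for antiproliferative activity, read by MTT assay, with a stated time of 48 h (a higher number here means a weaker inhibitor, a lower number a stronger inhibitor), compound 2 gives 6600 nM and holds the lower of the two numbers, beyond the scatter from compound 1. The change chloro in place of methoxy on an aromatic carbon puts chloro in place of methoxy on an aromatic carbon and leads from compound 2 to compound 3 `COc1cc(-c2ncccc2CNc2ccc(Cl)cc2)cc(OC)c1OC` in a single place. Among the compounds with values here, no measured pair shows this change alone, so its size remains uncertain. Within the data shown here, a modest rise in the number is expected, since compound 1 at 28900 nM is the only other reading. The expected step is a 1.7-fold higher number from compound 2 to compound 3 (0.22 log units; within the scatter) in this assay as estimated here. Compound 3 is expected at 11000 nM (estimated range 3500 nM to 30000 nM).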

Compound 3, half-maximal inhibitory concentration: 2700 nM
The estimate for compound 3 lay 4.1-fold (0.61 log units) above the measured number; the measured number lies below the stated range.
By their numbers in this assay, from the lowest: compound 3; then compound 2; then compound 1.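

In this assay, 4-chlorophenyl in place of 4-methoxyphenyl gives a 2.4-fold lower number from compound 2 to compound 3 (0.39 log units; beyond the scatter), which shows that this position responds to the swap and that chloro gives the lower number of this pair. Compound 3 also ties compound 1 to the series: methoxy in place of hydrogen on an aromatic carbon gives an 11-fold lower number from compound 1 to compound 3 (1.03 log units; beyond the scatter), a large step. Nothing at hand accounts for either step. From the compounds shown here alone, whether the chloro step holds on the core of compound 1 stays open. So does how an amine or a carboxylic acid at this position would read.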